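Carbamate variation on a PAK4 quinazoline amide

This account rests on a few compounds, and the source may have more. Where it says the series, first, only, none or still open, it means among the compounds named here.

Compound 1 `CC(C)C(=O)OCOC(=O)N1CCN(C(=O)c2nc(Nc3cc(C4CC4)[nH]n3)c3cc(Cl)ccc3n2)C[C@H]1C`: 51.6%
Compound 2 `C[C@@H]1CN(C(=O)c2nc(Nc3cc(C4CC4)[nH]n3)c3cc(Cl)ccc3n2)CCN1C(=O)OC(C)(C)C`: 22.7%
Compound 3 `C[C@@H]1CN(C(=O)c2nc(Nc3cc(C4CC4)[nH]n3)c3cc(Cl)ccc3n2)CCN1C(=O)OCc1ccccc1`: 74%

Three compounds share one core and differ only in the group carried on the oxygen of the carbamate. In an assay for inhibition of serine/threonine-protein kinase PAK 4 (Homo sapiens), read by FRET and Z'-LYTE, with a stated time of 60 min, tested at 5 uM, in the presence of a further agent that is not named here (on this read-out higher numbers stand for a stronger effect at the one concentration tested and lower numbers for a weaker effect), compound 3 gives 74%, the highest of the three numbers; compound 1 sits nearer, and compound 2 furthest away. Both gaps are beyond the scatter: a number 22.4 percentage points higher from compound 1 to compound 3 (beyond the scatter) and a number 51.3 percentage points higher from compound 2 to compound 3 (beyond the scatter). The remaining step, a number 28.9 percentage points lower from compound 1 to compound 2 (beyond the scatter), is modest.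

Compound 4 `CCCCCOC(=O)N1CCN(C(=O)c2nc(Nc3cc(C4CC4)[nH]n3)c3cc(Cl)ccc3n2)C[C@H]1C` is the next member. Its change from compound 3 is butyl in place of phenyl on a saturated chain carbon bound to an oxygen next to a carbonyl group; the same difference, cut one bond further out, reads benzyl to pentyl. The step from compound 2 to compound 3 shows that exchanging the whole carbamate substituent can move the read-out a long way, while the step from compound 1 to compound 3 shows a modest move for a change at the same place. Among the compounds with values here, no measured step goes from phenyl to butyl, so compound 4 is expected to fall between compound 2 and compound 3, with a downward step a number 19 percentage points lower from compound 3 to compound 4 (beyond the scatter) of modest size expected in this assay. For compound 4 the estimate is 55%, within 30% to 78%.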

Compound 4, a percentage reported as inhibition, at one concentration (the size of the read-out at that concentration, not a potency): 12.6%
Beside the measured number, compound 4's estimate is 42.4 percentage points above it; measured number outside the range, below it.
By their numbers in this assay, from the lowest: compound 4; then compound 2; then compound 1; then compound 3.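

In this assay, within the data shown here, exchanging the benzyl group of the carbamate for pentyl gives a number 61.4 percentage points lower from compound 3 to compound 4 (beyond the scatter), a larger move than any step among the earlier compounds, so an open chain of this kind does not stand in for the phenyl at this place. The pentyl carbamate also falls under the other two, with a number 10.1 percentage points lower from compound 2 to compound 4 (beyond the scatter) and a number 39 percentage points lower from compound 1 to compound 4 (beyond the scatter), which puts both simple alkyl carbamates, compound 2 and compound 4, at the low end of the series and the benzyl carbamate of compound 3 at the top, although compound 1 goes against any rule that a ring is needed, since it has none and still stands in the middle. Nothing available here accounts for these differences.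

The compounds shown leave open whether a saturated ring, as in a cyclohexylmethyl carbamate, would hold the read-out of the benzyl group, or whether the aromatic ring itself is what counts, and how a 2-phenylethyl carbamate or a pyridylmethyl carbamate would compare. Since each number comes from one concentration, they show only a stronger or weaker effect at that concentration and leave open how these compounds would compare at any other.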